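Carbamoyl to sulfamoyl on the shared core

This account rests on a few compounds, and the source may have more. Where it says the series, first, only, none or still open, it means among the compounds named here.

Measured in an ADME assay on TZM cells (Homo sapiens) for cytotoxicity, read by XTT assay, with a stated time of 4 days; on this read-out lower numbers stand for higher toxicity in this test and higher numbers for lower toxicity in this test:
- compound 1 `Cc1cc(CCC#N)cc(C)c1Oc1cc(Nc2ccc(C#N)cc2)c(N)cc1C(=O)O`: 14300 nM
- compound 2 `Cc1cc(CCC#N)cc(C)c1Oc1cc(Nc2ccc(C#N)cc2)c(N)cc1C(N)=O`: > 9400 nM

Compound 2 stands at > 9400 nM, which is a limit and not a number. Compound 3 `Cc1cc(CCC#N)cc(C)c1Oc1cc(Nc2ccc(C#N)cc2)c(N)cc1S(N)(=O)=O` carries sulfamoyl in place of carbamoyl on an aromatic carbon. Within the data shown here, the only measured step bearing on this is a step that the limit leaves unreadable from compound 1 to compound 2, and it has no readable size. No shift beyond the scatter is therefore expected in this assay, and the estimate leans on compound 1 at 14300 nM. This gives an expected step that the limit leaves unreadable from compound 2 to compound 3. For compound 3 the estimated value is 12000 nM, with an expected range of 5000 nM to 30000 nM.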

Compound 3, half-maximal cytotoxic concentration: 11100 nM
Compound 3: middle estimate off by 1.1-fold (0.03 log units), on the high side, and the stated range covers the measured number.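

In this assay, this position now has its first readable step: putting sulfamoyl in place of carboxy on the aromatic carbon gives a 1.3-fold lower number from compound 1 to compound 3 (0.11 log units; within the scatter). The two groups therefore cannot be told apart in this test. Compound 2 has only a limit, so the steps to and from it cannot be read: the limit of > 9400 nM in this assay, at which 1 of the 3 values shown sits.

As far as these compounds go, whether carbamoyl differs from either group therefore stays open. So does the reading for a quite different group at this position, such as a methyl ester or a simple amine.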